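A few compounds are considered here, and "the series" means these few. Any claim that something is new, unique, unknown or untested is made for them only; others in the source may bear on it.

Measured in a functional assay on A549 cells (Homo sapiens) for antiproliferative activity, read by MTT assay, with a stated time of 48 h; on this read-out higher numbers stand for weaker inhibition and lower numbers for stronger inhibition:
compound 1 `COc1ccc(-c2cn3cc(C4=CCN(C(=O)c5ccccc5C(F)(F)F)CC4)ccc3n2)cc1OC` — 2550 nM
compound 2 `COc1ccc(-c2cn3cc(C4=CCN(C(=O)c5ccccc5)CC4)ccc3n2)cc1OC` — 7700 nM
compound 3 `COc1ccc(-c2cn3cc(C4=CCN(S(=O)(=O)C5CCCC5)CC4)ccc3n2)cc1OC` — 6470 nM

Compound 3 stands second highest of the three numbers; a 1.2-fold lower number from compound 2 to compound 3 (0.08 log units; within the scatter), so compounds 2 and 3 cannot be told apart, whereas a 2.5-fold higher number from compound 1 to compound 3 (0.40 log units; beyond the scatter). Compound 4 `COc1ccc(-c2cn3cc(C4=CCN(S(=O)(=O)c5ccccc5)CC4)ccc3n2)cc1OC` is reached by phenyl in place of cyclopentyl on a sulfonyl sulfur. Within the data shown here, no measured step isolates this exchange. The closest is a 1.2-fold lower number from compound 2 to compound 3 (0.08 log units; within the scatter), where benzoyl became cyclopentylsulfonyl, combining the phenyl-for-cyclopentyl swap with carbonyl-to-sulfonyl, and that step stayed within the scatter. With nothing else bearing on it, no change beyond the scatter is expected. For compound 4 the expected step is a 1.1-fold lower number from compound 3 to compound 4 (0.03 log units; within the scatter). Compound 4 is estimated at 6000 nM, with a range from 2500 nM to 14000 nM.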

Compound 4, half-maximal inhibitory concentration: 7660 nM
For compound 4 the middle estimate is 1.3-fold (0.11 log units) below the measured one; measured number inside the range.
By their numbers in this assay, from the lowest: compound 1; then compounds 3, 4 and 2 (each within the scatter of the next).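

On the sulfonyl sulfur, phenyl and cyclopentyl cannot be told apart (a 1.2-fold higher number from compound 3 to compound 4 (0.07 log units; within the scatter)), nor can phenylsulfonyl and benzoyl on the amine nitrogen in a ring (a 1.0-fold lower number from compound 2 to compound 4 (0.00 log units; within the scatter)), so neither part of the earlier combined exchange moves the number beyond the scatter. Compound 1, with its trifluoromethyl, stays apart from the sulfonamide (a 3.0-fold higher number from compound 1 to compound 4 (0.48 log units; beyond the scatter)). No measurement on hand explains these steps.

Open: whether trifluoromethyl on the phenyl of compound 4 would lower the number, and whether an amine or a carboxylic acid on the sulfonyl sulfur would shift it beyond the scatter.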